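Trifluoromethyl for trifluoromethoxy in compound 4

The source may hold more compounds than are shown below. What is called first, only, known or untested is meant among the compounds shown, and "the series" means these compounds.

In a functional assay on KG-1 cells (Homo sapiens) for cytotoxicity, read by luminescence and CellTiter-Glo, with a stated time of 3 days (a higher number here means a weaker inhibitor, a lower number a stronger inhibitor), compound 3 `O=C(Nc1ccc(OC(F)(F)F)c(Cl)c1)c1cc(Cl)ccc1O` reads 460 nM and lies within the scatter of compound 2 `O=C(Nc1ccc(OC(F)(F)F)c(Cl)c1)c1cc(F)ccc1O` at 370 nM and of compound 1 `O=C(Nc1ccc(C(F)(F)F)cc1)c1cc(Cl)ccc1O` at 740 nM on the same scale. Compound 4 `O=C(Nc1ccc(C(F)(F)F)c(Cl)c1)c1cc(Cl)ccc1O` carries trifluoromethyl in place of trifluoromethoxy on an aromatic carbon and keeps the rest of compound 3 unchanged. Within the data shown here, no measured step tests this change directly. The nearest evidence is a different change, chloro in place of fluoro, where a 1.2-fold higher number from compound 2 to compound 3 (0.09 log units; within the scatter) is all that was seen. In this assay the estimated step is a 1.1-fold higher number from compound 3 to compound 4 (0.04 log units; within the scatter) and so none beyond the scatter is expected. Compound 4 is estimated at 500 nM with an expected range from 230 nM to 1000 nM in this measurement.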

Compound 4, half-maximal inhibitory concentration: 450 nM
Estimate against measurement, compound 4: 1.1-fold (0.05 log units) above; low and high end bracket the measured number.
By their numbers in this assay, from the lowest: compounds 2, 4, 3 and 1 (each within the scatter of the next).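

On this aromatic carbon, ortho to a chloro group, the exchange of trifluoromethoxy for trifluoromethyl gives a 1.0-fold lower number from compound 3 to compound 4 (0.01 log units; within the scatter) in this assay and so loses nothing measurable with the oxygen. Chloro in place of hydrogen on an aromatic carbon gives a 1.6-fold lower number from compound 1 to compound 4 (0.22 log units; within the scatter) and is likewise no step beyond the scatter. Nothing measured here bears on why either step stays this small.

The compounds shown leave open whether an amine, a carboxylic acid or a longer chain on this carbon would hold the number within the scatter. They also leave open whether any group here can produce a step beyond it.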